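The source may report more compounds than this note shows. Statements on the series, on what has been measured and on what is new or still open speak of the compounds shown alone.

Compound 1 `O=C1C(=O)N(CC(CO)NCCCNc2ccnc3cc(Cl)ccc23)c2ccccc21`, compound 2 `O=C1C(=O)N(CC(CO)NCCCNc2ccnc3cc(Cl)ccc23)c2ccc(Cl)cc21` and compound 3 `O=C1C(=O)N(CC(CO)NCCNc2ccnc3cc(Cl)ccc23)c2ccc(Cl)cc21` share a core and have been tested in an ADME assay on HCT-116 cells (Homo sapiens) for cytotoxicity, read by MTT assay, with a stated time of 48 h, tested at 2 uM; a lower number here means a weaker effect, a higher number a stronger effect of the compound at the concentration tested. In this assay compound 1 gives -12%, compound 2 gives 2% and compound 3 gives -11%. Compound 2 and compound 1 differ by one change, (hydrogen in place of chloro on an aromatic carbon), and that change produced a number 14 percentage points lower from compound 2 to compound 1 (beyond the scatter). The difference between the cores of compound 3 and compound 2 is not broken down here. Going by the values given here, compound 4 `O=C1C(=O)N(CC(CO)NCCNc2ccnc3cc(Cl)ccc23)c2ccccc21` has not yet been measured; it differs from compound 3 by hydrogen in place of chloro on an aromatic carbon, which is the same change as the one from compound 2 to compound 1. Compound 4 is expected to move by a number 9 percentage points lower from compound 3 to compound 4 (within the scatter), because the earlier step of a number 14 percentage points lower from compound 2 to compound 1 (beyond the scatter) went in that direction. Compound 4 is therefore estimated at -20%, with a likely range from -35% to -5%.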

Compound 4, a percentage reported as inhibition, at one concentration (the size of the read-out at that concentration, not a potency): 2%
Estimate against measurement, compound 4: 22 percentage points below; the whole stated range lies below it.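

In this assay, putting hydrogen in place of chloro on the aromatic carbon gives a number 13 percentage points higher from compound 3 to compound 4 (beyond the scatter). Set beside the earlier step, the same change does not carry over from one core to the other, not even in its direction: the same change on two cores in this assay, a number 14 percentage points lower (beyond the scatter) from compound 2 to compound 1 and a number 13 percentage points higher (beyond the scatter) from compound 3 to compound 4, 27 percentage points apart, beyond the scatter of two such steps This shows that, for these two pairs, the step measured on one core could not be transferred to the other, but two pairs do not show why the cores differ or how the change would behave on a further core.

The compounds shown leave open how a fluoro or a methoxy group on that same aromatic carbon would read in this assay. They also leave open whether a longer linking chain would give a step like either of these two.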